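The source may report more compounds than this note shows. Statements on the series, on what has been measured and on what is new or still open speak of the compounds shown alone.

Two measured compounds open this series. Compound 1 `COC(=O)[C@@H](C)NC(=O)[C@@H](C)NC(=O)CN(Cc1ccccn1)Cc1ccccn1` was tested in an ADME assay on MDA-MB-231 cells (Homo sapiens) for cytotoxicity, read by MTT assay, with a stated time of 72 h (on this read-out lower numbers stand for stronger inhibition and higher numbers for weaker inhibition), and compound 1 gives 184000 nM. Compound 2 `COC(=O)[C@@H](C)NC(=O)[C@@H](C)NC(=O)Cn1cc(CN(Cc2ccccn2)Cc2ccccn2)nn1` carries a triazole ring between the amide and the bis(pyridylmethyl)amine arm; in this assay compound 2 gives 152000 nM. Of the two numbers, that of compound 2 is the smaller, but the gap to compound 1 lies within the usual scatter of repeated measurements, so the two compounds cannot be told apart on these data.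

Compound 3 `COC(=O)[C@H](C)NC(=O)[C@H](C)NC(=O)Cn1cc(CN(Cc2ccccn2)Cc2ccccn2)nn1` is the next step: the two compounds have the same atoms and bonds and differ only in configuration as drawn: 2 of 2 stereo elements differ (all stereocentres are inverted: mirror images); a stereocentre at a saturated chain carbon is drawn R in compound 2 and S in compound 3; a stereocentre at a saturated chain carbon is drawn R in compound 2 and S in compound 3. Among the compounds with values here, no measured pair in this set shows what a full inversion of configuration does here, so there is no precedent to draw on. Compound 3 is therefore expected to sit close to compound 2, with an estimated step of a 1.1-fold higher number from compound 2 to compound 3 (0.02 log units; within the scatter), no larger than the scatter in either direction. The estimate for compound 3 is 160000 nM, with a range from 80000 nM to 320000 nM.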

Compound 3, half-maximal inhibitory concentration: 157000 nM
Beside the measured number, compound 3's estimate is 1.0-fold (0.01 log units) above it, and the stated range covers the measured number.
By their numbers in this assay, from the lowest: compounds 2, 3 and 1 (each within the scatter of the next).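

The earlier compounds shown here offered no pair that tested configuration, and this pair does: in this assay, inverting both stereocentres gives a 1.0-fold higher number from compound 2 to compound 3 (0.01 log units; within the scatter), so these mirror images cannot be told apart on these data. The comparison isolates configuration as the only variable: the fact that compounds 2 and 3 differ only in the configuration as drawn

Within the scatter of this cytotoxicity read-out, the drawn configuration of these two stereocentres therefore shows no detectable influence in this pair, although that finding applies only to this triazole-bearing structure and to inversion of both centres together. The compounds shown leave open what inverting just one of the two stereocentres would do. They also leave open whether the same lack of separation would hold if a carboxylic acid replaced the methyl ester at the end of the chain.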